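Anilino variation on a shared core in a cell assay

The source may hold more compounds than are shown below. What is called first, only, known or untested is meant among the compounds shown, and "the series" means these compounds.

Measured so far:
compound 1 `CC(C)c1ccc(-c2nc(SCc3cn(CC(=O)NC(=O)Nc4ccccn4)nn3)nc(Nc3ccccc3Cl)c2C#N)cc1` gives 23400 nM
compound 2 `COc1ccccc1Nc1nc(SCc2cn(CC(=O)NC(=O)Nc3ccccn3)nn2)nc(-c2ccc(C(C)C)cc2)c1C#N` gives 8960 nM

Both numbers come from a functional assay on ECa-109 cells (Homo sapiens) for inhibition, read by MTT assay, with a stated time of 72 h; a lower number here means a stronger inhibitor, a higher number a weaker inhibitor. Within the data shown here, compound 2 holds the lowest of the two numbers; compound 1 is the nearest and stands higher by a 2.6-fold lower number from compound 1 to compound 2 (0.42 log units; beyond the scatter), which is the only measured step, a methoxy in place of chloro on an aromatic carbon.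

Compound 3 `CC(C)c1ccc(Nc2nc(SCc3cn(CC(=O)NC(=O)Nc4ccccn4)nn3)nc(-c3ccc(C(C)C)cc3)c2C#N)cc1` is not yet measured. It differs from compound 2 by 4-isopropylphenyl in place of 2-methoxyphenyl on a nitrogen on an aromatic ring. Among the measured compounds shown here, no measured step covers this change: the one step available swaps a substituent on the same ring, and it is modest. Nothing here indicates that a different aryl on that nitrogen moves the number far, so compound 3 is expected to land near compound 2, with no step beyond the scatter, giving an expected step of a 1.0-fold higher number from compound 2 to compound 3 (0.00 log units; within the scatter).

The estimate for compound 3 in this assay is 9000 nM, expected to fall between 2500 nM and 32000 nM.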

Compound 3, half-maximal inhibitory concentration: 2490 nM
Estimate against measurement, compound 3: 3.6-fold (0.56 log units) above; measured number below the stated range.
By their numbers in this assay, from the lowest: compound 3; then compound 2; then compound 1.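

In this assay, compound 3 holds the lowest number of the three, and the aryl group on this nitrogen proves to be a working point of variation rather than a near-neutral one. Compared with the earlier change of substituent on the same 2-substituted phenyl ring, replacing that ring with 4-isopropylphenyl gives a 3.6-fold lower number from compound 2 to compound 3 (0.56 log units; beyond the scatter) and a 9.4-fold lower number from compound 1 to compound 3 (0.97 log units; beyond the scatter). No measured evidence on hand accounts for these steps.

The change alters both the group and its place on the ring, so the compounds shown do not separate the contribution of the isopropyl group from that of its location. An unsubstituted phenyl, or a ring carrying a carboxylic acid or an amine at the place the isopropyl group occupies in 4-isopropylphenyl, would test how specific the lower number is to this group.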